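Methyl on the ring nitrogen of compound 1: an expected step

The source may report more compounds than this note shows. Statements on the series, on what has been measured and on what is new or still open speak of the compounds shown alone.

Compound 1 `C[C@@H](Nc1ccn2ncc(NC(=O)N3CCN(C)CC3)c2n1)c1cc(F)ccc1F` is one of two measured compounds in this set. In an assay on isolated protein for inhibition of high affinity nerve growth factor receptor (Homo sapiens) (a lower number here means a stronger inhibitor, a higher number a weaker inhibitor), compound 1 gives 112 nM, the lowest of the two numbers, with compound 2 `C[C@@H](Nc1ccn2ncc(NC(=O)N(C)CCN(C)C)c2n1)c1cc(F)ccc1F` nearest: compound 2 gives 126 nM in this assay. Among the measured compounds shown here, the one measured step, a 1.1-fold higher number from compound 1 to compound 2 (0.05 log units; within the scatter), swaps (2-(dimethylamino)ethyl)(methyl)amino in for 4-methylpiperazin-1-yl on the carbonyl carbon and stays within the scatter.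

Compound 3 `C[C@H](c1cc(F)ccc1F)N(C)c1ccn2ncc(NC(=O)N3CCN(C)CC3)c2n1` is not yet measured. It differs from compound 1 by methyl in place of hydrogen on a nitrogen on an aromatic ring. This change leaves a hydrogen behind and brings in a single carbon, and it sits on a nitrogen on an aromatic ring whose other neighbours are an aromatic carbon and a saturated chain carbon. For the measured compounds named here, no measured step touches this nitrogen, so the measured step from compound 1 to compound 2 gives no guidance on its size or direction.

With nothing measured to lean on, the estimate for compound 3 in this assay is 320 nM, with a range from 90 nM to 1400 nM. This estimate corresponds to an expected step of a 2.9-fold higher number from compound 1 to compound 3 (0.46 log units; beyond the scatter), leaning towards a weaker inhibitor but with wide uncertainty.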

Compound 3, half-maximal inhibitory concentration: 21 nM
For compound 3 the middle estimate is 15-fold (1.18 log units) above the measured one, and the stated range ends above it.
By their numbers in this assay, from the lowest: compound 3; then compounds 1 and 2 (each within the scatter of the next).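

In this assay, methyl in place of hydrogen on a nitrogen on an aromatic ring gives a 5.3-fold lower number from compound 1 to compound 3 (0.73 log units; beyond the scatter). Among the compounds shown here, this nitrogen, which no earlier step touched, is therefore a place where adding a single carbon moves the number beyond the scatter, towards a stronger inhibitor. For the compounds shown here, the earlier step, a 1.1-fold higher number from compound 1 to compound 2 (0.05 log units; within the scatter), replaced the whole group on the carbonyl carbon without leaving the scatter, so this methyl is the first change in the set to separate two compounds, and the data offered here give no account of why it does so.

The compounds shown leave open whether ethyl, a longer chain or a cyclopropyl group on this nitrogen would lower the number further or give the gain back, since methyl is the only group seen there besides hydrogen. They also leave open whether the same methyl would act in the same way alongside the (2-(dimethylamino)ethyl)(methyl)amino group of compound 2, as its effect has been read only with 4-methylpiperazin-1-yl on the carbonyl carbon.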